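Methoxy in Place of Methylsulfanyl: Following Compound 2 to Compound 4

This account rests on a few compounds, and the source may have more. Where it says the series, first, only, none or still open, it means among the compounds named here.

Compound 1 `COc1ncnc2c1c(-c1ccoc1)cn2[C@@H]1O[C@H](CO)[C@@H](O)[C@H]1O`: 150 nM
Compound 2 `CSc1ncnc2c1c(-c1ccccc1)cn2[C@@H]1O[C@H](CO)[C@@H](O)[C@H]1O`: > 20000 nM
Compound 3 `O=c1[nH]cnc2c1c(-c1cccs1)cn2[C@@H]1O[C@H](CO)[C@@H](O)[C@H]1O`: > 20000 nM

In a functional assay on HL-60 cells (Homo sapiens) for antiproliferative activity, read by XTT assay, with a stated time of 72 h (a lower number here means a stronger inhibitor, a higher number a weaker inhibitor), compound 1 gives 150 nM. For compound 2 the result is only a limit of the assay, > 20000 nM. Compound 3 likewise stands at a limit, > 20000 nM. Among the compounds with values here, compound 2 therefore sits at the limit of > 20000 nM in this assay, at which 2 of the 3 values shown sit, and no step between measured compounds leads away from it. Compound 4 `COc1ncnc2c1c(-c1ccccc1)cn2[C@@H]1O[C@H](CO)[C@@H](O)[C@H]1O` differs from compound 2 by methoxy in place of methylsulfanyl on an aromatic carbon. Within the data shown here, compound 1 carries the same methoxy group and is the one compound with a number rather than a limit. The step from compound 2 to compound 4 is expected to be large, toward stronger inhibition, an at least 33-fold lower number from compound 2 to compound 4 (1.52 log units; beyond the scatter). Compound 4 is estimated at 600 nM, with a range from 100 nM to 8000 nM.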

Compound 4, half-maximal inhibitory concentration: > 20000 nM
Compound 4: only a limit was reported (the forecaster's own chance of this, stated with the estimate: 25%); middle value at least 33-fold (1.52 log units) away from the limit.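

In this assay compound 4 gives only a limit of the assay, > 20000 nM. Compound 2 is a limit as well, so the step from methylsulfanyl to methoxy cannot be read, and methoxy on this aromatic carbon does not by itself give a measurable value. With methoxy kept, phenyl in place of furan-3-yl on an aromatic carbon gives an at least 130-fold higher number from compound 1 to compound 4 (2.12 log units; beyond the scatter).

From the compounds shown here alone, it remains open whether methylsulfanyl and methoxy differ on a core that carries furan-3-yl. Going by these compounds, how an amine in place of methoxy would read on that core also remains open.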